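Compound 4: replacing the nitro group of compound 2

The compounds below may be only part of what the source reports. "The series", "measured", "known", "first", "only" and "open" are said of these compounds alone.

In a functional assay (trachea) for inhibition, with Cavia porcellus as the target (a higher number here means a weaker inhibitor, a lower number a stronger inhibitor), compound 2 `CC1(C)c2ccc([N+](=O)[O-])cc2[C@@H](n2ccccc2=O)[C@@H]1O` gives 150 nM, the lower of the two true numbers in the series. The other number belongs to compound 1 `CC1(C)c2ccc([N+](=O)[O-])cc2[C@@H](N2CCCC2=O)[C@@H]1O`, which gives 2800 nM. Compound 3 `CC1(C)c2cc(C(F)(F)F)ccc2[C@@H](n2ccccc2=O)[C@@H]1O` gives > 20000 nM, which is a limit of the assay and not a number.

Compound 4 `CC1(C)c2ccc(N)cc2[C@@H](n2ccccc2=O)[C@@H]1O` is the next point. It carries amino in place of nitro on an aromatic carbon of a six-membered aromatic ring of carbon only, meta to a fused ring and para to a fused ring: amino in place of nitro on an aromatic carbon.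

For the measured compounds named here, no measured step changes this group. Going by the values given here, the one measured step, a 19-fold lower number from compound 1 to compound 2 (1.27 log units; beyond the scatter), lies on a saturated ring carbon, and both of its compounds keep the nitro. It bears only on scale, showing that a change in one place can move the number well beyond the scatter. The expected direction rests on compound 3, which has trifluoromethyl and no nitro and gives > 20000 nM, again a limit. This is thin support from a single compound.

The expected change is a higher number in this assay, beyond the scatter: a 20-fold higher number from compound 2 to compound 4 (1.30 log units; beyond the scatter). For compound 4 the estimated value is 3000 nM, with an expected range of 500 nM to 20000 nM.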

Compound 4, half-maximal inhibitory concentration: > 20000 nM
Compound 4: no number, only a limit; the forecaster's own chance of this, stated with the estimate: 25%; at least 6.6-fold (0.82 log units) between middle value and limit.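

In this assay, for the compounds shown here, amino in place of nitro on an aromatic carbon gives the first measured step at this position, and it is large: an at least 130-fold higher number from compound 2 to compound 4 (2.12 log units; beyond the scatter). Compound 4 gives > 20000 nM, which is a limit of the assay and not a number. The earlier step lay on a saturated ring carbon with the nitro kept on both sides, whereas this one shows that a change at the aromatic carbon alone, with the rest of compound 2 held constant, is enough to take a measurable number to the limit, so the step gives only a lower bound on the size of the change: the limit of > 20000 nM in this assay, at which 2 of the 4 values shown sit.

From the compounds shown here alone, with only nitro and amino compared directly at this carbon, it remains open whether a different group there, such as a nitrile or a carboxylic acid, would keep the number close to that of compound 2. Also open, going by these compounds, is whether the step on the saturated ring carbon, a 19-fold lower number from compound 1 to compound 2 (1.27 log units; beyond the scatter), would carry over with such a group in place of nitro.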